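Compound 3: piperazin-1-yl replacing the hydroxymethylpiperidinyl group

A few compounds are considered here, and "the series" means these few. Any claim that something is new, unique, unknown or untested is made for them only; others in the source may bear on it.

Within the data shown here, compound 2 `OCC1CCCCN1c1nc(-c2cc(-c3ccon3)n(Cc3ccccc3F)n2)ncc1F` gives the lowest of the two numbers so far in an assay on a protein complex for activation of soluble guanylate cyclase (Homo sapiens), read by cGMP accumulation, in the presence of a further agent that is not named here (on this read-out higher numbers stand for an effect only at larger amounts of compound and lower numbers for an effect already at smaller amounts), at 35 nM; the nearest is compound 1 `Fc1ccccc1Cn1nc(-c2ncc(F)c(OCC3CC3)n2)cc1-c1ccon1`, which gives 2300 nM. Among the measured compounds shown here, the one measured step, a 66-fold lower number from compound 1 to compound 2 (1.82 log units; beyond the scatter), is the only guide. Compound 3 `Fc1ccccc1Cn1nc(-c2ncc(F)c(N3CCNCC3)n2)cc1-c1ccon1` is unmeasured; it differs from compound 2 as follows: piperazin-1-yl in place of 2-(hydroxymethyl)piperidin-1-yl on an aromatic carbon. For the measured compounds named here, no measured pair tests this exchange, and the step from compound 1 to compound 2 involved a different group, so it bears only loosely on it. A moderate loss with wide uncertainty is expected for compound 3, a 5.7-fold higher number from compound 2 to compound 3 (0.76 log units; beyond the scatter). Compound 3 is expected to give 200 nM in this assay, within 50 nM to 1000 nM.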

Compound 3, half-maximal effective concentration: 120 nM
The estimate for compound 3 lay 1.7-fold (0.22 log units) above the measured number; low and high end bracket the measured number.
By their numbers in this assay, from the lowest: compound 2; then compound 3; then compound 1.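

At this position on the aromatic ring, the gain over cyclopropylmethoxy in this assay is not confined to 2-(hydroxymethyl)piperidin-1-yl: piperazin-1-yl also gives a large step (a 19-fold lower number from compound 1 to compound 3 (1.28 log units; beyond the scatter)). The difference between the two non-aromatic rings is only modest (a 3.4-fold higher number from compound 2 to compound 3 (0.54 log units; beyond the scatter)), so most of the gain is kept with either group. No evidence on hand explains these steps.

On these data alone, compounds 2 and 3 differ in the hydroxymethyl group and the second ring nitrogen at once, so the share of each stays open. As far as these compounds go, how plain piperidin-1-yl or morpholin-4-yl would read here is also open.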